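The source may report more compounds than this note shows. Statements on the series, on what has been measured and on what is new or still open speak of the compounds shown alone.

Compound 1 `CCc1ccc2nc(C(=O)Nc3c(F)cc(-c4cccc(F)c4)cc3F)c(C)c(O)c2c1`: 2.05%
Compound 2 `CCc1ccc2nc(C(=O)Nc3c(F)cc(-c4cccc(F)c4)cc3F)c(C)c(C(=O)O)c2c1`: -0.05%

In a functional assay on Hep 3B2 cells (Homo sapiens) for antiproliferative activity, read by MTT assay, with a stated time of 24 h, tested at 0.02 ug/mL (a lower number here means a weaker effect, a higher number a stronger effect of the compound at the concentration tested), compound 1 gives 2.05%. Compound 2 gives -0.05%, the lowest of the two numbers, though the step of a number 2.1 percentage points lower from compound 1 to compound 2 (within the scatter) lies within the scatter, so the two compounds are not distinguished. Compound 3 `Cc1c(C(=O)Nc2c(F)cc(-c3cccc(F)c3)cc2F)nc2ccc(C(F)(F)F)cc2c1C(=O)O` differs from compound 2 by trifluoromethyl in place of ethyl on an aromatic carbon. Going by the values given here, no measured step touches this position, so nothing bears directly on the change. With both known compounds near zero effect, no step beyond the scatter is expected, and a number 1.1 percentage points higher from compound 2 to compound 3 (within the scatter) is the estimated step. Compound 3 is therefore expected to give 1%, in a range from -8% to 10%.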

Compound 3, a percentage reported as inhibition, at one concentration (the size of the read-out at that concentration, not a potency): 1.15%
The estimate for compound 3 lay 0.2 percentage points below the measured number; measured number inside the range.
By their numbers in this assay, from the lowest: compounds 2, 3 and 1 (each within the scatter of the next).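

Replacing ethyl with trifluoromethyl on the carbon-only aromatic ring, with the carboxy group kept, gives a number 1.2 percentage points higher from compound 2 to compound 3 (within the scatter) in this assay and so does not distinguish the two compounds. Going by these compounds alone, this is the first measured change at this position, and it adds no separation to the earlier pair. No evidence on the cause of this result is available.

Going by these compounds, all three values lie close to zero at this single concentration, so it remains open whether the position matters in a compound with a clear effect. Also open, on these data alone, is whether an amine or a longer chain there would read differently.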